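The source may hold more compounds than are shown below. What is called first, only, known or untested is meant among the compounds shown, and "the series" means these compounds.

Of the compounds shown here, three have been measured. In a functional assay on B16-F0 cells (Mus musculus) for inhibition, read by CCK-8 assay, with a stated time of 48 h (on this read-out higher numbers stand for weaker inhibition and lower numbers for stronger inhibition), compound 1 `Cn1ccc2cc(-c3cc4nccc(-c5ccc(F)cc5)n4n3)ccc21` gives 4780 nM. Compound 2 `COc1cc(-c2cc3nccc(-c4c[nH]c5ccccc45)n3n2)cc(OC)c1OC` reaches only the limit of this assay, > 10000 nM, so no number is known for it. Compound 3 `COc1ccc(-c2cc3nccc(-c4cc(OC)c(OC)c(OC)c4)n3n2)cc1F` gives 3950 nM in this assay, a number that sits within the usual scatter of the number for compound 1, so the two cannot be told apart.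

Compound 4 `COc1cc(-c2ccnc3cc(-c4ccc(F)cc4)nn23)cc(OC)c1OC` has not yet been measured. It differs from compound 3 in one place: 4-fluorophenyl in place of 3-fluoro-4-methoxyphenyl on an aromatic carbon. Among the measured compounds shown here, no measured pair differs in only this way, so there is no direct guide to the size of the step. The step from compound 3 to compound 4 is expected to stay within the scatter, a 1.1-fold higher number from compound 3 to compound 4 (0.06 log units; within the scatter). Compound 4 is therefore estimated at 4500 nM, between 1500 nM and 13000 nM.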

Compound 4, half-maximal inhibitory concentration: 4540 nM
The estimate for compound 4 lay 1.0-fold (0.00 log units) below the measured number; measured number inside the range.
By their numbers in this assay, from the lowest: compounds 3, 4 and 1 (each within the scatter of the next). At a limit, above all of these: compound 2.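

In this assay, the first step read at this position, on an aromatic carbon next to the ring nitrogen, is a 1.1-fold higher number from compound 3 to compound 4 (0.06 log units; within the scatter). Exchanging 3-fluoro-4-methoxyphenyl for the smaller 4-fluorophenyl, which has no hydrogen-bond acceptor, therefore leaves the number unchanged within the scatter, though this rests on a single pair. Nothing measured here accounts for so small a step. As far as these compounds go, whether a group without an aromatic ring, such as an amine or a carboxylic acid, would be tolerated at this position stays open.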